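A few compounds are considered here, and "the series" means these few. Any claim that something is new, unique, unknown or untested is made for them only; others in the source may bear on it.

Going by the values given here, in an ADME assay on HepG2 cells (Homo sapiens) for cytotoxicity, with a stated time of 72 h (a lower number here means that less compound is needed, a higher number that more compound is needed for the effect), compound 2 `O=C(Nc1nc(-c2cccc(F)c2)cs1)c1cc([N+](=O)[O-])ccc1Cl` gives 18000 nM, the only exact number available so far. The reading for compound 1 `O=C(Nc1nc(-c2ccc(Cl)cc2)cs1)c1cc([N+](=O)[O-])ccc1Cl` is > 27000 nM, which is a limit and not a number. Compound 3 `O=C(Nc1nc(-c2ccc(F)c(F)c2)cs1)c1cc([N+](=O)[O-])ccc1Cl` differs from compound 2 by one small edit: fluoro in place of hydrogen on an aromatic carbon. This places fluoro in place of hydrogen on an aromatic carbon, turning 3-fluorophenyl into 3,4-difluorophenyl. Among the compounds with values here, only one measured step bears on this edit: an at least 1.5-fold lower number from compound 1 to compound 2 (0.17 log units; that floor lies within the scatter). It also changes the substituted phenyl group, and it starts from the limit (the limit of > 27000 nM in this assay, at which 1 of the 2 values shown sits). Going by that single step from compound 1, whose floor stays within the scatter, no clear shift is expected in this assay. The expected change is a 1.1-fold higher number from compound 2 to compound 3 (0.05 log units; within the scatter), which would remain within the scatter. The estimate for compound 3 is 20000 nM, with an expected range from 10000 nM to 36000 nM.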

Compound 3, half-maximal effective concentration: > 27000 nM
Compound 3: a limit, no number (the forecaster's own chance of this, stated with the estimate: 30%); middle value at least 1.3-fold (0.13 log units) away from the limit.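

In this assay, adding a fluoro group ortho to the fluoro group of 3-fluorophenyl gives an at least 1.5-fold higher number from compound 2 to compound 3 (0.17 log units; that floor lies within the scatter), so this edit causes no shift that can be told apart from the scatter. Compound 3 gives > 27000 nM, which is a limit and not a number, and its step from compound 1 cannot be read, since both values are limits. Of the compounds shown, only compound 2, with hydrogen at this position, has an exact number, and the limit is now the most common reading: the limit of > 27000 nM in this assay, at which 2 of the 3 values shown sit.

Going by these compounds, how far beyond the limit compound 3 lies remains open. It is also unknown whether an amine, a methoxy group or a carboxylic acid at this position would give an exact number in this assay.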